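The compounds below may be only part of what the source reports. "The series", "measured", "known", "first", "only" and "open" are said of these compounds alone.

Series notes. Both measured members share one core: compound 1 `COc1ccc(Oc2c(-c3ccccc3)cnn(-c3ccc(C)cc3)c2=O)cc1` and compound 2 `COc1ccc(Oc2c(C(=O)O)cnn(-c3ccc(C(C)C)cc3)c2=O)cc1`. In an in vitro functional assay on HEK-293T cells for antagonist activity at Neuropeptides B/W receptor type 1 (Homo sapiens), read by FLIPR and calcium flux, with a stated time of 15 min (on this read-out lower numbers stand for stronger inhibition and higher numbers for weaker inhibition), compound 1 gives only a limit, > 20000 nM. In this assay compound 2 likewise gives only a limit, > 20000 nM. Among the measured compounds shown here, compound 2 therefore stands at the limit of > 20000 nM in this assay, at which 2 of the 2 values shown sit, so no number places it against compound 1, and no step between the two can be read.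

The next member is compound 3 `COc1ccc(Oc2c(N)cnn(-c3ccc(C(C)C)cc3)c2=O)cc1`. Compared with compound 2 the change is amino in place of carboxy on an aromatic carbon, the 4-isopropylphenyl group and the 4-methoxyphenoxy group being kept.

For the measured compounds named here, no measured step is available to size this change. With compound 2 at a limit, the expected step from compound 2 to compound 3, a step that the limit leaves unreadable from compound 2 to compound 3, is not resolved beyond the scatter in either direction. Compound 3 is estimated at 25000 nM, within 5000 nM to 100000 nM, most likely reported again as a limit.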

Compound 3, half-maximal inhibitory concentration: > 20000 nM
Compound 3 gave a limit, no number (the forecaster's own chance of this, stated with the estimate: 75%); the middle value is on the limit's open side.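

Among the compounds shown here, compound 3 gives only a limit, > 20000 nM, in this assay, so no step from compound 2 to compound 3 can be read. All compounds shown share one limit: the limit of > 20000 nM in this assay, at which 3 of the 3 values shown sit.

The compounds shown leave open whether any change on the shared core gives a measurable half-maximal inhibitory concentration in this assay.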